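This account rests on a few compounds, and the source may have more. Where it says the series, first, only, none or still open, it means among the compounds named here.

In a functional assay on Bel7402/5-FU cells (Homo sapiens) for antiproliferative activity, read by MTT assay, with a stated time of 72 h (a lower number here means a stronger inhibitor, a higher number a weaker inhibitor), the measured compounds read as follows:

compound 1 `C=C1C(=O)O[C@H]2[C@H]1CC/C(COC(=O)Cn1cc(F)c(=O)n(Cc3ccc([N+](=O)[O-])cc3)c1=O)=C\CC[C@@]1(C)O[C@@H]21` gives 4340 nM
compound 2 `C=C1C(=O)O[C@H]2[C@H]1CC/C(COC(=O)Cn1cc(F)c(=O)n(Cc3cccc(F)c3)c1=O)=C\CC[C@@]1(C)O[C@@H]21` gives 3700 nM
compound 3 `C=C1C(=O)O[C@H]2[C@H]1CC/C(COC(=O)Cn1cc(F)c(=O)n(Cc3ccc(F)cc3F)c1=O)=C\CC[C@@]1(C)O[C@@H]21` gives 5010 nM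

Compound 3 cannot be separated from the other two, since both of its steps lie within the scatter (a 1.2-fold higher number from compound 1 to compound 3 (0.06 log units; within the scatter)) and (a 1.4-fold higher number from compound 2 to compound 3 (0.13 log units; within the scatter)). Compound 4 `C=C1C(=O)O[C@H]2[C@H]1CC/C(COC(=O)Cn1cc(F)c(=O)n(Cc3cc(F)ccc3F)c1=O)=C\CC[C@@]1(C)O[C@@H]21` is still unmeasured. It carries 2,5-difluorophenyl in place of 2,4-difluorophenyl on a saturated chain carbon bound to an aromatic nitrogen. For the measured compounds named here, no measured step shows this exact exchange. The closest evidence is the other exchanges of the aryl group at that same place, including the one from 4-nitrophenyl to 3-fluorophenyl (a 1.2-fold lower number from compound 1 to compound 2 (0.07 log units; within the scatter)), and none of them leaves the scatter in this assay. Going by the values given here, with only three compounds, this is thin support. For compound 4 no step beyond the scatter is expected (a 1.1-fold lower number from compound 3 to compound 4 (0.05 log units; within the scatter)). The estimated value for compound 4 is 4500 nM (expected range 2700 nM to 7500 nM).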

Compound 4, half-maximal inhibitory concentration: 4610 nM
For compound 4 the middle estimate is 1.0-fold (0.01 log units) below the measured one; low and high end bracket the measured number.
By their numbers in this assay, from the lowest: compounds 2, 1, 4 and 3 (each within the scatter of the next).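

In this assay, for the compounds shown here, the exchange of 2,4-difluorophenyl for 2,5-difluorophenyl on a saturated chain carbon bound to an aromatic nitrogen is the first step between two aryl groups with the same atoms, and it stays within the scatter (a 1.1-fold lower number from compound 3 to compound 4 (0.04 log units; within the scatter)). Fluoro in place of hydrogen on an aromatic carbon also stays within it (a 1.2-fold higher number from compound 2 to compound 4 (0.10 log units; within the scatter)), as does 2,5-difluorophenyl in place of 4-nitrophenyl (a 1.1-fold higher number from compound 1 to compound 4 (0.03 log units; within the scatter)), so all four aryl groups at this place now read alike. No supporting data bear on why this position reads so flat.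

The compounds shown carry only fluoro or nitro on the aryl ring. As far as these compounds go, whether an amine or a carboxylic acid on that ring, or a longer chain to the aromatic nitrogen, would leave the scatter in this assay remains open.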